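This account rests on a few compounds, and the source may have more. Where it says the series, first, only, none or still open, it means among the compounds named here.

This account follows the change from compound 3 to compound 4 in an ADME assay on Akata cells (Homo sapiens) for cytotoxicity, with a stated time of 7 days; on this read-out lower numbers stand for higher toxicity in this test and higher numbers for lower toxicity in this test. Compound 3, `CCOc1nc(N)nc2c1ncn2/C=C1/CC1(CO)CO`, belongs to a small set of three close relatives built on a shared core. In this assay compound 3 gives > 20000 nM, which is a limit of the measurement rather than a number. Compound 1, `CCCCSc1nc(N)nc2c1ncn2/C=C1/CC1(CO)CO`, is the butylsulfanyl counterpart. In this assay compound 1 gives > 20000 nM, again a limit. Compound 2, `CCCCCCSc1nc(N)nc2c1ncn2/C=C1/CC1(CO)CO`, carries hexylsulfanyl instead. In this assay compound 2 gives > 20000 nM, likewise a limit. Hence the steps a step that the two limits leave unreadable from compound 1 to compound 2, a step that the two limits leave unreadable from compound 1 to compound 3 and a step that the two limits leave unreadable from compound 2 to compound 3 cannot be sized, because all three measurements sit at the limit of > 20000 nM in this assay, at which 3 of the 3 values shown sit. Compound 4 is `Nc1nc(SC2CCCC2)c2ncn(/C=C3/CC3(CO)CO)c2n1`; it differs from compound 3 by cyclopentylsulfanyl in place of ethoxy on an aromatic carbon. For the measured compounds named here, no measured step bears readably on this change; the three limits show only that neither the longer chains nor the change to ethoxy brought toxicity into the measurable range. Compound 4 is therefore expected to show a step that the limit leaves unreadable from compound 3 to compound 4, with no readable step. Compound 4 is estimated at 30000 nM, with a range from 20000 nM to 200000 nM, and most likely again only a limit.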

Compound 4, half-maximal cytotoxic concentration: > 20000 nM
Compound 4 ended at the assay's limit; the forecaster's own chance of this, stated with the estimate: 85%; the middle value lies beyond the limit too.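

In this assay compound 4 gives > 20000 nM, again a limit. Its steps from compound 1, compound 2 and compound 3 therefore cannot be read: the limit of > 20000 nM in this assay, at which 4 of the 4 values shown sit.

The compounds shown leave open whether these groups on the shared core differ at all in this assay, since none of the four has a measured number.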